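Bromo to methoxy on compound 2

The compounds below may be only part of what the source reports. "The series", "measured", "known", "first", "only" and "open" are said of these compounds alone.

Values in a functional assay on DU-145 cells (Homo sapiens) for inhibition, read by trypan blue exclusion, with a stated time of 96 h; a lower number here means a stronger inhibitor of growth, a higher number a weaker inhibitor of growth:
compound 1 `COc1cc(/C=C(/Sc2ccc(Br)cc2)C(=O)c2ccc(Br)cc2)ccc1O` gives 1000 nM
compound 2 `O=C(/C(=C\c1ccc(Br)cc1)Sc1ccc(Br)cc1)c1ccc(Br)cc1` gives 1000 nM
compound 3 `O=C(/C(=C\c1c[nH]c2ccccc12)Sc1ccc(Br)cc1)c1ccc(Br)cc1` gives 1000 nM

On these numbers, compound 2 stands level with compound 1 and compound 3. Compound 4 `COc1ccc(S/C(=C/c2ccc(Br)cc2)C(=O)c2ccc(Br)cc2)cc1` carries methoxy in place of bromo on an aromatic carbon, para to a large group, so that (4-bromophenyl)sulfanyl becomes (4-methoxyphenyl)sulfanyl (methoxy in place of bromo on an aromatic carbon). The measured steps all lie at another place, on a double-bonded chain carbon: no change at the digits printed from compound 1 to compound 2 (within the scatter), no change at the digits printed from compound 1 to compound 3 (within the scatter) and no change at the digits printed from compound 2 to compound 3 (within the scatter) each remain within the scatter. For the measured compounds named here, no measured compound varies the (4-bromophenyl)sulfanyl group, so these steps offer only indirect guidance. From compound 2 at 1000 nM and those steps, no step beyond the scatter is expected in this assay, in either direction. The expected step is no change at the digits printed from compound 2 to compound 4 (within the scatter). The estimate for compound 4 is 1000 nM, with an expected range from 400 nM to 2500 nM.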

Compound 4, concentration for 50% growth inhibition: 20000 nM
Compound 4: middle estimate off by 20-fold (1.30 log units), on the low side; the measured number lies above the stated range.
By their numbers in this assay, from the lowest: compounds 1, 2 and 3 (each within the scatter of the next); then compound 4.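

In this assay, the (4-bromophenyl)sulfanyl group is the only place among the compounds shown where a change moves the number beyond the scatter: methoxy in place of bromo gives a 20-fold higher number from compound 2 to compound 4 (1.30 log units; beyond the scatter) and so a weaker inhibitor of growth. The three exchanges on the double-bonded chain carbon, among compounds 1, 2 and 3, had all stayed within the scatter, so a flat response at that place did not carry over to this aromatic carbon. The data shown offer no explanation for the size of this step.

This single step cannot tell whether the loss follows from removing bromo or from adding methoxy, and a chloro, a hydroxyl or an amine at the same aromatic carbon would help separate the two. It also leaves open whether methoxy in place of the other bromo groups would change the number in the same way.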